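Adding a Methyl Group: Expected Shift in Lipophilicity

The source may hold more compounds than are shown below. What is called first, only, known or untested is meant among the compounds shown, and "the series" means these compounds.

Of the compounds shown here, three have so far been measured in a physicochemical assay for lipophilicity; on this read-out higher numbers stand for higher lipophilicity and lower numbers for lower lipophilicity. Compound 1, `CCCCOc1ccc(-c2[nH]c3ccccc3c2C2=C(Br)C(=O)NC2=O)cc1`, gives 3.87 in this assay. Compound 2, `CCCCCOc1ccc(-c2[nH]c3ccccc3c2C2=C(Br)C(=O)NC2=O)cc1`, gives 4.2. Compound 3, `Cc1ccc2[nH]c(-c3ccccc3)c(C3=C(Br)C(=O)NC3=O)c2c1`, gives 2.88, the lowest of the three numbers, and its nearest neighbour among them is compound 1.

Compounds 1 and 2 differ in one place: methyl in place of hydrogen on a saturated chain carbon, four bonds along the chain from an oxygen on an aromatic ring. In this assay the change brought a number 0.33 log units higher from compound 1 to compound 2 (beyond the scatter).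

Compound 4, `CCc1ccc2[nH]c(-c3ccccc3)c(C3=C(Br)C(=O)NC3=O)c2c1`, has not yet been measured. It differs from compound 3 in one place: methyl in place of hydrogen on a saturated chain carbon bound to an aromatic carbon. Within the data shown here, this is the same kind of change as the one seen between compounds 1 and 2, though the surroundings are not identical: in compound 2 the new methyl sits on a saturated chain carbon, four bonds along the chain from an oxygen on an aromatic ring, whereas in compound 4 it sits on a saturated chain carbon bound to an aromatic carbon. How the core of compound 3 differs from the core of compound 1 is not broken down here.

For compound 4 the expected step in this assay is a number 0.37 log units higher from compound 3 to compound 4 (beyond the scatter). That expectation rests on the measured step of a number 0.33 log units higher from compound 1 to compound 2 (beyond the scatter), which came from the same kind of change. Compound 4 is therefore estimated at 3.25, with a likely range from 2.95 to 3.6.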

Compound 4, partition coefficient: 3.15
The estimate for compound 4 lay 0.10 log units above the measured number; the measured number falls inside the stated range.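

In this assay, the same swap of hydrogen for methyl gave a number 0.27 log units higher from compound 3 to compound 4 (within the scatter), set against a number 0.33 log units higher from compound 1 to compound 2 (beyond the scatter) on the core of compound 1. The two steps point the same way, which fits the idea that this change can be carried from one core to the other, but the step on the core of compound 3 cannot be told apart from the ordinary spread of repeat measurements, so on its own it does not establish a real difference between compound 3 and compound 4. With only one pair on each core, and the new methyl sitting in a different place in each pair, these results set no general size for the change and do not show whether the core or the surroundings of the chain affect it, and no measurement shown here offers an explanation for how the two steps read.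

The compounds shown leave open how a longer chain, such as propyl in place of the ethyl group of compound 4, would read on this core. They also leave open whether an amine or a carboxylic acid at the end of that chain would read any differently from the plain chains seen so far.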